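Swapping the Amide Aryl Group for a Plain Phenyl

This account rests on a few compounds, and the source may have more. Where it says the series, first, only, none or still open, it means among the compounds named here.

Of the compounds shown here, three share one core and have been tested in a functional assay on SF-295 cells (Homo sapiens) for inhibition, read by sulforhodamine B assay, with a stated time of 48 h; on this read-out lower numbers stand for stronger inhibition and higher numbers for weaker inhibition. Compound 1, `COc1cc(-c2nn(-c3cccc(NC(=O)Nc4ccc(Cl)c(Cl)c4)c3)cc2-c2ccncc2)ccc1Cl`, carries a urea and gives 690 nM. Compound 2, `COc1cc(-c2nn(-c3cccc(NC(=O)Nc4cccc(C(F)(F)F)c4)c3)cc2-c2ccncc2)ccc1Cl`, also a urea, gives 310 nM, and the change between them was a 2.2-fold lower number from compound 1 to compound 2 (0.35 log units; beyond the scatter). Compound 3, `COc1cc(-c2nn(-c3cccc(NC(=O)c4ccc(Cl)c(C(F)(F)F)c4)c3)cc2-c2ccncc2)ccc1Cl`, replaces the urea with an amide and gives 1380 nM. This is the highest number of the three: the move from the first urea was a 2.0-fold higher number from compound 1 to compound 3 (0.30 log units; within the scatter), while the move from the second was a 4.5-fold higher number from compound 2 to compound 3 (0.65 log units; beyond the scatter).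

Compound 4, `COc1cc(-c2nn(-c3cccc(NC(=O)c4ccccc4)c3)cc2-c2ccncc2)ccc1Cl`, is the next compound to be tested. Its difference from compound 3 is phenyl in place of 4-chloro-3-(trifluoromethyl)phenyl on a carbonyl carbon. Going by the values given here, no measured step changes the aryl group on the amide, so the closest guide is the step from compound 1 to compound 2, in which a change of aryl substituents on the urea moved this assay only modestly. The amide itself sits at the weaker end of the set. A modest shift is therefore expected, and since two substituents are removed rather than exchanged, the expected direction for compound 4 is toward a somewhat higher number, with a 1.8-fold higher number from compound 3 to compound 4 (0.26 log units; within the scatter) as the estimated step. Compound 4 is expected to give about 2500 nM in this assay, plausibly between 800 nM and 8000 nM.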

Compound 4, half-maximal inhibitory concentration: 340 nM
Compound 4: the middle estimate sits 7.4-fold (0.87 log units) above what was measured; the whole stated range lies above it.
By their numbers in this assay, from the lowest: compounds 2 and 4 (each within the scatter of the next); then compounds 1 and 3 (each within the scatter of the next).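

In this assay, stripping the aryl group on the carbonyl carbon down to plain phenyl lowers the number rather than raising it (a 4.1-fold lower number from compound 3 to compound 4 (0.61 log units; beyond the scatter)), so the substituents of 4-chloro-3-(trifluoromethyl)phenyl are not needed here, and the high number of compound 3 cannot be blamed on the amide link alone. Compound 4 also stands level with the urea compound 2 (a 1.1-fold higher number from compound 2 to compound 4 (0.04 log units; within the scatter)) and gives a lower number than the other urea (a 2.0-fold lower number from compound 1 to compound 4 (0.31 log units; beyond the scatter)), so among these compounds a urea is not required to reach this range. No measurement is at hand that explains why the bare ring does better than the substituted one.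

The compounds shown remove the chlorine and the trifluoromethyl group only together, so it stays open whether one of them alone accounts for the higher number of compound 3. Also open, going by these compounds, is how the number would respond to a different group on the phenyl ring, such as an amine, a carboxylic acid or a methoxy group.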